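A few compounds are considered here, and "the series" means these few. Any claim that something is new, unique, unknown or untested is made for them only; others in the source may bear on it.

Compound 1, with the structure `Cc1ccc2c(NCc3ccc(NC(=O)C4CCN(Cc5ncc[nH]5)CC4)cc3)nc(N(C)C)nc2c1`, is inactive in a functional assay on SV5A8 cells (Homo sapiens) for cytotoxicity (a lower number here means a stronger inhibitor, a higher number a weaker inhibitor), at the limit > 20000 nM, which is a limit of the assay and not a number. Compound 2, `Cc1ccc2c(NCc3ccc(NC(=O)C4CCN(Cc5ccccc5)CC4)cc3)nc(N(C)CCN(C)C)nc2c1`, is likewise read only as a limit in this assay, at > 8830 nM. Compound 3, `Cc1ccc2c(NCc3ccc(NC(=O)C4CCN(Cc5ccccc5)CC4)cc3)nc(N(C)CCCN(C)C)nc2c1`, gives in this assay > 8620 nM, again a limit. Among the compounds with values here, the one step between measured compounds, a step that the two limits leave unreadable from compound 2 to compound 3, therefore cannot be read in size or direction, since both ends sit at limits. Within the data shown here, compound 1 itself stands at the limit of > 20000 nM in this assay, at which 1 of the 3 values shown sits, and no step from it to any other measured compound exists. Compound 4, `Cc1ccc2c(NCc3ccc(NC(=O)C4CCN(Cc5ccco5)CC4)cc3)nc(N(C)C)nc2c1`, differs from compound 1 by furan-2-yl in place of 1H-imidazol-2-yl on a saturated chain carbon bound to an amine nitrogen in a ring. Among the measured compounds shown here, no measured step touches the group on that saturated chain carbon, and the single step from compound 2 to compound 3 that is recorded lies elsewhere on the core and is unreadable. Compound 4 is therefore expected to remain at the limit of this assay, and its estimate is 20000 nM, in the range 8000 nM to 50000 nM. The step of a number no higher from compound 1 to compound 4 (the limit leaves the size open) is expected to be none beyond the scatter.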

Compound 4, half-maximal inhibitory concentration: > 20000 nM
Compound 4: no number, only a limit; the forecaster's own chance of this, stated with the estimate: 80%; the middle value lies on the limit itself.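

Compound 1 and compound 4 both stand only at a limit of this assay, not at a number, and the step between them cannot be read: the limit of > 20000 nM in this assay, at which 2 of the 4 values shown sit.

The compounds shown leave open whether any group on that saturated chain carbon would give a readable value in this assay.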